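Stepping From Isopropyl to Isobutyl on a Shared Core

A few compounds are considered here, and "the series" means these few. Any claim that something is new, unique, unknown or untested is made for them only; others in the source may bear on it.

Of the compounds shown here, two with a shared core have been measured in an assay on Sf9 cells for inhibition of serine/threonine-protein kinase 4 (Homo sapiens), read by luminescence and ADP-Glo, with a stated time of 1 h, in the presence of a further agent that is not named here; a lower number here means a stronger inhibitor, a higher number a weaker inhibitor. Compound 1 `CC1C(=O)N(C)c2cnc(Nc3ccc(S(N)(=O)=O)cc3)nc2N1C` carries a methyl group on a saturated ring carbon, and in this assay compound 1 gives 313 nM. Compound 2 `CC(C)C1C(=O)N(C)c2cnc(Nc3ccc(S(N)(=O)=O)cc3)nc2N1C` carries an isopropyl group instead, and in this assay compound 2 gives 254 nM. The step of a 1.2-fold lower number from compound 1 to compound 2 (0.09 log units; within the scatter) shows that growing this group from methyl to isopropyl did not shift the number beyond the scatter. Among the compounds with values here, of the two numbers measured so far, compound 2 sits at the lower end, though its gap to compound 1 is within the scatter, so the two cannot be told apart.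

Within the data shown here, compound 3 `CC(C)CC1C(=O)N(C)c2cnc(Nc3ccc(S(N)(=O)=O)cc3)nc2N1C` is the next compound. isobutyl in place of isopropyl on a saturated ring carbon Only one measured step bears on this change, the one from methyl to isopropyl, and it stayed within the scatter. The expected step is therefore a 1.1-fold lower number from compound 2 to compound 3 (0.02 log units; within the scatter), with no movement beyond the scatter. Compound 3 is estimated at 240 nM in this assay, in a range from 110 nM to 520 nM.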

Compound 3, half-maximal inhibitory concentration: 77 nM
Compound 3: the middle estimate sits 3.1-fold (0.49 log units) above what was measured; measured number below the stated range.
By their numbers in this assay, from the lowest: compound 3; then compounds 2 and 1 (each within the scatter of the next).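

Within the data shown here, the isobutyl group is the first change at this saturated ring carbon to move the number beyond the scatter in this assay, with a 3.3-fold lower number from compound 2 to compound 3 (0.52 log units; beyond the scatter), whereas the step from methyl to isopropyl stayed within it. Isobutyl differs from isopropyl by only one carbon, 4 carbons against 3, yet the comparison with the methyl compound makes the contrast sharper: an isopropyl group placed on a saturated chain carbon bound to a saturated ring carbon gives a 4.1-fold lower number from compound 1 to compound 3 (0.61 log units; beyond the scatter), while an isopropyl group carried directly on the ring carbon, as in compound 2, gives a number within the scatter of compound 1. Across these three compounds, then, the number does not simply follow the size of the group, and how the carbons are arranged in it matters at least as much as how many there are, though no measurement at hand explains why.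

The compounds shown leave open whether the number keeps falling with a longer chain, such as n-pentyl, or with a benzyl group at this carbon. They also leave open whether the gain survives when an amine or a carboxylic acid is placed at the end of the chain.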